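Oxolane Replaces Methylcyclopropyl on an Aminoquinoline Ether

This account rests on a few compounds, and the source may have more. Where it says the series, first, only, none or still open, it means among the compounds named here.

Of the compounds shown here, two have been measured in an assay on cells with melanin-concentrating hormone receptor 1 (Homo sapiens) as the target, read by radioligand binding; a higher number here means a weaker inhibitor, a lower number a stronger inhibitor. Compound 1 `CC1CC1COc1cccc2ccc(N)nc12` gives 1640 nM in this assay, the higher of the two numbers and so the weaker inhibitor of the pair. Compound 2 `CNc1ccc2cccc(OC(C)CC(C)(C)C)c2n1` gives 310 nM in this assay, a difference from compound 1 that lies beyond the scatter; as the two compounds differ in more than one place, no single change can be read from this gap.

Compound 3 `Nc1ccc2cccc(OCC3CCOC3)c2n1` has not yet been measured. It differs from compound 1 in one place, (oxolan-3-yl in place of 2-methylcyclopropyl on a saturated chain carbon bound to an oxygen on an aromatic ring). For the measured compounds named here, no measured pair shows this change, so its effect is unknown. Compound 3 is expected to give about 2400 nM in this assay, within a range of 700 nM to 8000 nM. This estimate means a step of a 1.5-fold higher number from compound 1 to compound 3 (0.17 log units; within the scatter), a small move toward a weaker inhibitor, close to the scatter of repeated measurements.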

Compound 3, half-maximal inhibitory concentration: 115 nM
Compound 3: middle estimate off by 21-fold (1.32 log units), on the high side; measured number outside the range, below it.
By their numbers in this assay, from the lowest: compound 3; then compound 2; then compound 1.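

The change from 2-methylcyclopropyl to oxolan-3-yl on a saturated chain carbon bound to an oxygen on an aromatic ring gives in this assay a 14-fold lower number from compound 1 to compound 3 (1.15 log units; beyond the scatter) and so is a large step. For the compounds shown here, it is the first single change that can be read here, and it shows that the number in this assay responds strongly to the group at this place, with the shared core unchanged. The entering group brings a ring oxygen and a hydrogen-bond acceptor that the leaving group lacks, but no measurement on hand explains the step.

As far as these compounds go, whether the ring oxygen itself matters stays open, and cyclopentyl at the same place would set oxolan-3-yl against an all-carbon ring. From the compounds shown here alone, it also remains open whether the step would hold on a core bearing a methylamino group.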